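The compounds below may be only part of what the source reports. "The series", "measured", "known", "first", "only" and "open" are said of these compounds alone.

Notes on the series around compound 1 `COc1cc(NC(C)CCCNC(=O)NNC(=O)N(CCO)CCO)c2ncccc2c1`.

Compound 1 carries on the terminal carbonyl a bis(2-hydroxyethyl)amino group. In a functional assay on HeLa cells (Homo sapiens) for inhibition, read by MTT assay, with a stated time of 4 days (on this read-out higher numbers stand for weaker inhibition and lower numbers for stronger inhibition), compound 1 returns only a limit, > 250000 nM, not a number. Compound 2 `COc1cc(NC(C)CCCNC(=O)NNC(=O)Nc2ccc(Cl)c(C(F)(F)F)c2)c2ncccc2c1` has (4-chloro-3-(trifluoromethyl)phenyl)amino on that carbonyl carbon and gives 17000 nM in this assay. Compound 3 `COc1ccc(/C(=N/NC(=O)NNC(=O)NCCCC(C)Nc2cc(OC)cc3cccnc23)c2ccccc2)cc1`, a hydrazone-bearing analogue, gives 18000 nM in this assay. Going by the values given here, the one measured step is an at least 14-fold lower number from compound 1 to compound 2 (1.16 log units; beyond the scatter), so compound 1 sits at the weak end of the three values, and the limit of > 250000 nM in this assay, at which 1 of the 3 values shown sits, marks where it stands.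

Compound 4 `COc1cc(NC(C)CCCNC(=O)NN)c2ncccc2c1` differs from compound 1 by hydrogen in place of bis(2-hydroxyethyl)carbamoyl on an amine nitrogen. Among the compounds with values here, no measured step removes this group to a bare hydrogen; the only step from compound 1 replaces it with an aryl carbamoyl. Since that step was large, the trimmed analogue is expected to move off the limit of compound 1, but less than compound 2 did: an expected step of an at least 2.0-fold lower number from compound 1 to compound 4 (0.31 log units; beyond the scatter). Compound 4 is therefore estimated at 120000 nM in this assay, with a range from 25000 nM to 400000 nM, and a limit again is plausible.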

Compound 4, half-maximal inhibitory concentration: >= 250000 nM
Compound 4 gave a limit, no number; the forecaster's own chance of this, stated with the estimate: 45%; at least 2.0-fold (0.31 log units) between middle value and limit.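

In this assay compound 4 returns a limit, >= 250000 nM, not a number. Going by these compounds alone, compound 1 also returns only a limit, > 250000 nM, so no step between compound 1 and compound 4 can be read. The compounds shown leave open what the bis(2-hydroxyethyl)carbamoyl group contributes to this read-out.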